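Nitrile to Cyclopropylmethoxy on the Aryl Ring

The compounds below may be only part of what the source reports. "The series", "measured", "known", "first", "only" and "open" are said of these compounds alone.

Three compounds have been measured in a functional assay on aorta for antagonist activity at Alpha-1D adrenergic receptor (Rattus norvegicus); a higher number here means weaker binding, a lower number tighter binding:

compound 1 `COc1ccccc1N1CCN(CCCNc2ncccc2C(=O)C2CC2)CC1` gives 2 nM
compound 2 `COc1ccccc1N1CCN(CCCNc2nc(C)cc(C)c2C(N)=O)CC1` gives 39.8 nM
compound 3 `CN(C)C(=O)c1cccnc1NCCCN1CCN(c2ccccc2C#N)CC1` gives 10 nM

Compound 3 stands with the second highest number of the three. Its nearest neighbour is compound 2, whose number is higher by a margin beyond the scatter; the furthest is compound 1, whose number is lower, again beyond the scatter. Going by the values given here, none of the three measured compounds differs from another in a single place, so no measured step exists from which the next change could be read directly.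

Compound 4 `CN(C)C(=O)c1cccnc1NCCCN1CCN(c2ccccc2OCC2CC2)CC1` is the compound still to be measured in this assay. It differs from compound 3 in one place: cyclopropylmethoxy in place of cyano on an aromatic carbon. Among the compounds with values here, the only guide is that compound 1 and compound 2, each carrying an alkoxy group on that ring, bracket compound 3 on either side, one tighter and one weaker, so the present data give no single direction for the exchange.

The step from compound 3 to compound 4 is therefore expected to be modest, a 1.3-fold lower number from compound 3 to compound 4 (0.10 log units; within the scatter), with either direction possible. Compound 4 is estimated to give 8 nM in this assay, with a range from 2 nM to 30 nM.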

Compound 4, dissociation constant: 10 nM
The estimate for compound 4 lay 1.3-fold (0.10 log units) below the measured number; the measured number falls inside the stated range.
By their numbers in this assay, from the lowest: compound 1; then compounds 3 and 4 (each within the scatter of the next); then compound 2.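

In this assay the exchange of cyano for cyclopropylmethoxy on an aromatic carbon ortho to a large group gives no change at the digits printed from compound 3 to compound 4 (within the scatter) and so leaves the reading unmoved. Going by these compounds alone, this is the first single-place comparison in the set, and it shows that this position can take a group of 5 heavy atoms with a three-membered ring in place of one of 2 heavy atoms with a triple bond, with no change beyond the scatter. The hydrogen-bond donor and acceptor counts of the two groups are the same, but no measurement here explains why the reading holds, and it is not possible to say whether the two groups act on the receptor in the same way.

The compounds shown leave open whether the position would hold the same reading with a group of another kind, such as a primary amine, a carboxylic acid or a longer chain like hexyloxy. Steps from compound 3 or compound 4 to compound 1 or compound 2 cannot be read, as those pairs differ in more than one place, so the effect of the amide on the shared core also remains open.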